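Swapping Phenyl for Benzyl on a Fused Ring Nitrogen

The source may hold more compounds than are shown below. What is called first, only, known or untested is meant among the compounds shown, and "the series" means these compounds.

Of the compounds shown here, three sharing a dihydroxy-acid side chain have been tested in an in vivo functional assay on the whole organism for inhibition of 3-hydroxy-3-methylglutaryl-coenzyme A reductase (Rattus norvegicus), at a dose of 0.2 mg/kg by the oral route; on this read-out lower numbers stand for a weaker effect and higher numbers for a stronger effect at the one dose given. Compound 1 `Cc1cc2nc(C3CC3)c(/C=C/[C@@H](O)C[C@@H](O)CC(=O)O)c(-c3ccc(F)cc3)n2n1` gives -27.1%, compound 3 `CC(C)c1nc2onc(-c3ccccc3)c2c(-c2ccc(F)cc2)c1/C=C/[C@@H](O)C[C@@H](O)CC(=O)O` gives 33.7%, and compound 2 `Cc1nn(-c2ccccc2)c2nc(C(C)C)c(/C=C/[C@@H](O)C[C@@H](O)CC(=O)O)c(-c3ccc(F)cc3)c12` gives 3.3%. Compound 2 therefore stands second highest of the three, with compound 1 lying below it and compound 3 above it, each at a distance beyond the usual scatter, so the order of the three is real.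

Compound 4 `Cc1nn(Cc2ccccc2)c2nc(C(C)C)c(/C=C/[C@@H](O)C[C@@H](O)CC(=O)O)c(-c3ccc(F)cc3)c12` differs from compound 2 in one place: benzyl in place of phenyl on an aromatic nitrogen, on the ring nitrogen of the fused two-ring core. No pair of measured compounds isolates this kind of change, so nothing shown gives its direction or size. The expectation, then, is a step from compound 2 to compound 4 of a number 1.7 percentage points higher from compound 2 to compound 4 (within the scatter) in this assay, which may well fall within the scatter, with a wide band of doubt. On that basis compound 4 is estimated at 5%, somewhere between -25% and 35%.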

Compound 4, a percentage reported as inhibition, in the whole organism at one dose (the size of the read-out at that dose, not a potency): 16.4%
For compound 4 the middle estimate is 11.4 percentage points below the measured one; the range from low to high includes it.
By their numbers in this assay, from the lowest: compound 1; then compound 2; then compound 4; then compound 3.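

On the ring nitrogen of the fused two-ring core, benzyl in place of phenyl gives, in this assay, a number 13.1 percentage points higher from compound 2 to compound 4 (beyond the scatter), so the read-out at this one dose is sensitive to which of these two groups sits on this nitrogen. The change is a small one by count: both groups hold one six-membered aromatic ring of carbon only and no hydrogen-bond donors or acceptors, with benzyl at 7 heavy atoms against 6 for phenyl. Nothing measured here accounts for the rise.

As far as these compounds go, whether a longer chain such as phenylethyl, or a chain ending in an amine, would carry the number further on this nitrogen remains open. Whether the step between these two compounds would hold at other doses is also unknown.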